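The source may report more compounds than this note shows. Statements on the series, on what has been measured and on what is new or still open speak of the compounds shown alone.

Of the compounds shown here, three sharing one core have been measured so far. Compound 3 `C=CC(=O)N1C(=O)CCSc2ccccc21` carries a hydrogen on the saturated ring carbon of its seven-membered ring, and in a functional assay on NB-4 cells (Homo sapiens) for cytotoxicity, read by CCK-8 assay, with a stated time of 24 h (on this read-out lower numbers stand for stronger inhibition and higher numbers for weaker inhibition), compound 3 gives 22400 nM, the lowest number of the three. Compound 2 `C=CC(=O)N1C(=O)CC(C)Sc2ccccc21` bears a methyl at that carbon, and in this assay compound 2 gives 227000 nM. Compound 1 `C=CC(=O)N1C(=O)CC(c2ccc(-c3ccccc3)cc2)Sc2ccccc21` bears a 4-phenylphenyl there, and in this assay compound 1 gives 57700 nM, a higher number than compound 3 but a much lower one than compound 2.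

Compound 4 `C=CC(=O)N1C(=O)CC(c2ccc(C#N)cc2)Sc2ccccc21` differs from compound 3 by 4-cyanophenyl in place of hydrogen on a saturated ring carbon, the new group sitting on the saturated ring carbon next to the ring sulfur. Among the measured compounds shown here, only one step between measured compounds touches this carbon: a 10-fold lower number from compound 2 to compound 3 (1.01 log units; beyond the scatter). For the measured compounds named here, no step with an aryl group there has been measured, so the pair compound 1 and compound 3 can only be read from its two values, which show a higher number once an aryl group occupies that carbon.

Taking that reading, compound 4 is expected to land above compound 3, with the step of a 2.0-fold higher number from compound 3 to compound 4 (0.30 log units; within the scatter). Compound 4 is therefore estimated at 45000 nM in this assay, within 15000 nM to 130000 nM.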

Compound 4, half-maximal inhibitory concentration: 62400 nM
Estimate against measurement, compound 4: 1.4-fold (0.14 log units) below; low and high end bracket the measured number.
By their numbers in this assay, from the lowest: compound 3; then compounds 1 and 4 (each within the scatter of the next); then compound 2.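

In this assay, 4-cyanophenyl in place of hydrogen on the saturated ring carbon gives a 2.8-fold higher number from compound 3 to compound 4 (0.44 log units; beyond the scatter) and so lies beyond the scatter, which gives a directly measured step for an aryl group at this carbon. The same group in place of methyl gives a 3.6-fold lower number from compound 2 to compound 4 (0.56 log units; beyond the scatter) at that carbon, so compound 1 and compound 4 both lie between the hydrogen of compound 3 and the methyl of compound 2. Cyano in place of phenyl on the aromatic carbon gives a 1.1-fold higher number from compound 1 to compound 4 (0.03 log units; within the scatter) and stays within the scatter, so these two aryl groups cannot be told apart in this assay. The data shown offer no explanation for any of these differences.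

The compounds leave open whether an amine or a carboxylic acid on that aromatic carbon would separate from compound 1 and compound 4. They also leave open whether an unsubstituted phenyl or a longer chain on the saturated ring carbon would fall nearer compound 3 or compound 2.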